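The source may hold more compounds than are shown below. What is called first, only, known or untested is meant among the compounds shown, and "the series" means these compounds.

Measured in a functional assay (aorta) with Oryctolagus cuniculus as the target; a lower number here means tighter binding, a higher number weaker binding:
- compound 1 `COc1cc(C(C)=O)ccc1OCCCN1CCC(C(c2ccccc2)c2ccccc2)CC1` gives 6.31 nM
- compound 2 `COc1cc(C(C)=O)ccc1OCCCN1CCC(C(c2ccccc2)c2ccc(F)cc2)CC1` gives 6.31 nM
- compound 3 `COc1ccc(C(c2ccc(OC)cc2)C2CCN(CCCOc3ccc(C(C)=O)cc3OC)CC2)cc1` gives 10 nM

Compound 2 stands at 6.31 nM, the same digits as compound 1. Compound 3 at 10 nM lies within the scatter of compound 2.

The next step leads to compound 4 `COc1cc(C(C)=O)ccc1OCCCN1CCC(C(c2ccc(F)cc2)C2CCCCC2)CC1`, with cyclohexyl in place of phenyl on a saturated chain carbon bound to an aromatic carbon and a saturated ring carbon.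

Going by the values given here, only one measured step is available, no change at the digits printed from compound 1 to compound 2 (within the scatter), and it is a fluoro in place of hydrogen on an aromatic carbon. It bears on the new change only indirectly, since it leaves both aromatic rings in place. Among the compounds with values here, no measured compound has a saturated ring at this carbon, so the data do not show the size of this change directly. The three numbers do sit close together, and on that thin basis no step beyond the scatter is expected in this assay, with a slight lean towards a higher number and a wide margin in both directions.

The estimated step is a 1.9-fold higher number from compound 2 to compound 4 (0.28 log units; within the scatter). For compound 4 the expected value is 12 nM. The estimated range for compound 4 runs from 3 nM to 45 nM.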

Compound 4, dissociation constant: 5.01 nM
Compound 4: middle estimate off by 2.4-fold (0.38 log units), on the high side, within the range that was stated.
By their numbers in this assay, from the lowest: compounds 4, 1, 2 and 3 (each within the scatter of the next).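

In this assay, cyclohexyl in place of phenyl on a saturated chain carbon bound to an aromatic carbon and a saturated ring carbon gives a 1.3-fold lower number from compound 2 to compound 4 (0.10 log units; within the scatter), so, for this pair, a non-aromatic ring of carbon only serves as well at this place as an aromatic one. The earlier step, no change at the digits printed from compound 1 to compound 2 (within the scatter), changed only a hydrogen on an aromatic carbon and left both aromatic rings in place, whereas this step replaces one of the rings itself while keeping the same count of 6 heavy atoms. Nothing available here explains why the number stays within the scatter across this change.

The compounds shown leave open whether a second cyclohexyl can also replace the remaining fluorine-bearing aromatic ring at this carbon, and whether the fluoro group still makes no difference once cyclohexyl is present. Also open, on these data alone, is whether the ring is needed at all, which a tert-butyl group or a methyl group at this carbon would test, and whether an amine or a carboxylic acid on the cyclohexyl ring would hold the number at this level.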